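This account rests on a few compounds, and the source may have more. Where it says the series, first, only, none or still open, it means among the compounds named here.

Of the compounds shown here, three sharing one core have been tested in an in vitro functional assay on HEK ts201 cells for antagonist activity at Neuronal acetylcholine receptor; alpha4/beta2 (Homo sapiens), read by fluorescence and calcium flux; on this read-out lower numbers stand for stronger inhibition and higher numbers for weaker inhibition. Compound 1, `COc1ccc(OCCCCCN2CCCC(COC(=O)c3ccccc3N3C(=O)CC(C)C3=O)C2)cc1`, gives 14500 nM in this assay and stands at the lowest of the three numbers. Compound 2, `CC1CC(=O)N(c2ccccc2C(=O)OCC2CCCN(CCCCCOc3ccccc3)C2)C1=O`, gives 17000 nM, and compound 3, `CC1CC(=O)N(c2ccccc2C(=O)OCC2CCCN(CCCCCCc3ccccc3)C2)C1=O`, gives 29500 nM. All measured steps alter the group at the far end of the chain: a 1.2-fold higher number from compound 1 to compound 2 (0.07 log units; within the scatter), a 2.0-fold higher number from compound 1 to compound 3 (0.31 log units; beyond the scatter) and a 1.7-fold higher number from compound 2 to compound 3 (0.24 log units; within the scatter). None of them touches the part of the molecule that changes in the unmeasured compound 4, `COc1ccc(OCCCCCN2CCCC(COC(=O)c3ccccc3-c3ccccc3)C2)cc1`. Compound 4 differs from compound 1 as follows: phenyl in place of 3-methyl-2,5-dioxopyrrolidin-1-yl on an aromatic carbon. Within the data shown here, no measured step therefore bears on this exchange directly; the measured steps only show that changes elsewhere move the number modestly, and the chain end of compound 1 is kept unchanged in compound 4. Among the measured compounds shown here, with no precedent for swapping a ring of this kind for a phenyl on the core, the size and direction of the step are uncertain, and the most reasonable expectation is a number for compound 4 close to that of compound 1 with a wide range on either side. Compound 4 is thus estimated at 15000 nM, expected to lie between 4000 nM and 60000 nM. That estimate means a 1.0-fold higher number from compound 1 to compound 4 (0.01 log units; within the scatter), an expected step with no direction claimed beyond the scatter.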

Compound 4, half-maximal inhibitory concentration: 14500 nM
Compound 4: middle estimate off by 1.0-fold (0.01 log units), on the high side, and the stated range covers the measured number.
By their numbers in this assay, from the lowest: compounds 1, 4, 2 and 3 (each within the scatter of the next, the first and the last beyond it).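

In this assay, among these compounds, the exchange of the 3-methyl-2,5-dioxopyrrolidin-1-yl group for phenyl gives no change at the digits printed from compound 1 to compound 4 (within the scatter) and is the first measured step at this aromatic carbon, since all earlier steps altered the far end of the chain. The two groups are far from alike on paper: the one that leaves is a five-membered non-aromatic ring of 8 heavy atoms with 2 hydrogen-bond acceptors and 2 double bonds outside aromatic rings, whereas the one that enters is a six-membered aromatic ring of 6 carbon atoms with no hydrogen-bond acceptors, yet in this pair these differences come with no measurable shift in the number. No measurement at hand explains this flat step.

On these data alone, both compounds carry the same 4-methoxyphenoxy chain end, so it remains open whether the same exchange would also leave the number unmoved with the phenoxy end of compound 2 or the benzyl end of compound 3. Also open, as far as these compounds go, is what a different group on this aromatic carbon, such as an amine or a carboxylic acid, would do to the number.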